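The compounds below may be only part of what the source reports. "The series", "measured", "known", "first", "only" and "open" are said of these compounds alone.

Working notes on chain length in four compounds sharing one core: compound 1 `CCCCCCOC(=O)CCC(=O)N1CCN(CCCOc2cc3c(Nc4ccc(F)c(Cl)c4)ncnc3cc2OC)CC1`, compound 2 `CCCCCCCCCCCCCOC(=O)CCC(=O)N1CCN(CCCOc2cc3c(Nc4ccc(F)c(Cl)c4)ncnc3cc2OC)CC1`, compound 3 `CCCCCCCCCCCCCCOC(=O)CCC(=O)N1CCN(CCCOc2cc3c(Nc4ccc(F)c(Cl)c4)ncnc3cc2OC)CC1` and the not yet measured compound 4 `CCCCCCCCCCCCCCCCCCOC(=O)CCC(=O)N1CCN(CCCOc2cc3c(Nc4ccc(F)c(Cl)c4)ncnc3cc2OC)CC1`. In a functional assay on A549 cells (Homo sapiens) for cytotoxicity, read by MTT assay, with a stated time of 24 h, tested at 40 uM (on this read-out lower numbers stand for a stronger effect and higher numbers for a weaker effect at the one concentration tested), compound 1 gives 74.2%, compound 2 gives 71.1% and compound 3 gives 88.6%. Compound 3 stands highest of the three numbers, that is with the weakest effect at the concentration tested. The lengthening steps have been uneven: a number 3.1 percentage points lower from compound 1 to compound 2 (within the scatter), while a number 14.4 percentage points higher from compound 1 to compound 3 (beyond the scatter) and a number 17.5 percentage points higher from compound 2 to compound 3 (beyond the scatter).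

The change from compound 3 to compound 4 is butyl in place of hydrogen on a saturated chain carbon, ten or more bonds along the chain from an oxygen next to a carbonyl group. The step that bears on it most directly is the one at the same place, from compound 2 to compound 3, which was modest and upward; the longer lengthening from compound 1 to compound 2 stayed within the scatter. Taken together they point to a small upward step or none beyond the scatter, with the read-out already near its ceiling. Compound 4 is therefore expected to give about 91% in this assay, between 77% and 103%. This estimate corresponds to an expected a number 2.4 percentage points higher from compound 3 to compound 4 (within the scatter).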

Compound 4, a percentage reported as activity, at one concentration (the size of the read-out at that concentration, not a potency): 91%
Estimate against measurement, compound 4: no gap at the digits printed; the range from low to high includes it.
By their numbers in this assay, from the lowest: compounds 2 and 1 (each within the scatter of the next); then compounds 3 and 4 (each within the scatter of the next).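

In this assay, the methyl step at this place was beyond the scatter, but adding butyl at the same place gives a number 2.4 percentage points higher from compound 3 to compound 4 (within the scatter), so the further lengthening gives no separable change. Compound 4 remains apart from the two shorter members, with a number 19.9 percentage points higher from compound 2 to compound 4 (beyond the scatter) and a number 16.8 percentage points higher from compound 1 to compound 4 (beyond the scatter), so the four numbers form two pairs, compounds 1 and 2 and compounds 3 and 4, rather than a steady climb with chain length. No measurement at hand accounts for this split.

Still open, from the compounds shown here alone, is whether a longer chain than that of compound 4 would stay with compounds 3 and 4, or whether a chain ending in an amine or a carboxylic acid would shift the read-out. With a single concentration, these numbers also leave potency across the series unresolved.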